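Saturated chain step from compound 2 to compound 3

This account rests on a few compounds, and the source may have more. Where it says the series, first, only, none or still open, it means among the compounds named here.

Measured in a functional assay on MGC-803 cells (Homo sapiens) for antiproliferative activity, read by MTT assay, with a stated time of 48 h; a lower number here means a stronger inhibitor, a higher number a weaker inhibitor:
- compound 1 `COc1ccc(CN(C(=O)CCSc2nc3ccccc3o2)c2cc(OC)c(OC)c(OC)c2)cc1`: 640 nM
- compound 2 `COc1ccc(CN(C(=O)CCCSc2nc3ccccc3o2)c2cc(OC)c(OC)c(OC)c2)cc1`: 1290 nM

Compound 2, at 1290 nM, lies within the scatter of compound 1. Compound 3 `COc1ccc(CN(C(=O)CCCCSc2nc3ccccc3o2)c2cc(OC)c(OC)c(OC)c2)cc1` differs from compound 2 by ((1,3-benzoxazol-2-yl)sulfanyl)methyl in place of (1,3-benzoxazol-2-yl)sulfanyl on a saturated chain carbon, three bonds along the chain from a carbonyl carbon. Among the measured compounds shown here, one measured step bears on this: the same change, two bonds along the chain from a carbonyl carbon, gave a 2.0-fold higher number from compound 1 to compound 2 (0.30 log units; within the scatter). That single step is thin support. The step expected in this assay is of similar size and in the same direction, a 1.6-fold higher number from compound 2 to compound 3 (0.19 log units; within the scatter). Compound 3 is estimated at 2000 nM, with an expected range of 800 nM to 5000 nM.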

Compound 3, half-maximal inhibitory concentration: 1360 nM
Compound 3: middle estimate off by 1.5-fold (0.17 log units), on the high side, within the range that was stated.
By their numbers in this assay, from the lowest: compounds 1, 2 and 3 (each within the scatter of the next, the first and the last beyond it).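

In this assay the change to ((1,3-benzoxazol-2-yl)sulfanyl)methyl three bonds along the chain from a carbonyl carbon gives a 1.1-fold higher number from compound 2 to compound 3 (0.02 log units; within the scatter) and so separates the two compounds by nothing measurable. Among the compounds shown here, the larger change to 2-((1,3-benzoxazol-2-yl)sulfanyl)ethyl gives a 2.1-fold higher number from compound 1 to compound 3 (0.33 log units; beyond the scatter) and is the only step that clears the scatter, though only modestly. No measurement gives a reason for these numbers.

As far as these compounds go, whether a longer chain stays level with compound 3 remains open. So does the outcome of an amine in place of the sulfanyl link.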